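Dimethylamino in place of methoxy on a carbonyl carbon

The compounds below may be only part of what the source reports. "The series", "measured", "known", "first", "only" and "open" are said of these compounds alone.

Going by the values given here, in an ADME assay on MT4 cells (Homo sapiens) for cytotoxicity, read by MTT assay, with a stated time of 4 days (on this read-out higher numbers stand for lower toxicity in this test and lower numbers for higher toxicity in this test), compound 1 (`COC(=O)c1[nH]cc(C(=O)NCc2ccc(F)cc2)c(=O)c1O`) gives 19000 nM, the only exact number available so far. Compound 2 (`O=C(NCCO)c1[nH]cc(C(=O)NCc2ccc(F)cc2)c(=O)c1O`) gives > 200000 nM, and this is a limit of the assay, not a number. Compound 3 (`CN(C)C(=O)c1[nH]cc(C(=O)NCc2ccc(F)cc2)c(=O)c1O`) has not yet been measured. Its difference from compound 1 is as follows: dimethylamino in place of methoxy on a carbonyl carbon. The methoxycarbonyl of compound 1 thus becomes a dimethylcarbamoyl, and the rest of the structure stays the same.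

Among the compounds with values here, only one measured step bears on this change: an at least 10-fold higher number from compound 1 to compound 2 (1.02 log units; beyond the scatter), a large step, with (2-hydroxyethyl)amino in place of methoxy on a carbonyl carbon. As far as these compounds go, its full size is unknown, as it ends at a limit. Within the data shown here, with only this single step from compound 1 to compound 2 as a guide, a higher number is expected in this assay, though probably by less, as dimethylamino is a different group. The expected change is a 3.7-fold higher number from compound 1 to compound 3 (0.57 log units; beyond the scatter). For compound 3 the estimated value is 70000 nM, with an expected range of 20000 nM to 200000 nM.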

Compound 3, half-maximal cytotoxic concentration: 5100 nM
Estimate against measurement, compound 3: 14-fold (1.14 log units) above, outside the stated range (below it).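

In this assay, dimethylamino in place of methoxy on a carbonyl carbon gives a 3.7-fold lower number from compound 1 to compound 3 (0.57 log units; beyond the scatter), the opposite direction to an at least 10-fold higher number from compound 1 to compound 2 (1.02 log units; beyond the scatter), so among these compounds replacing methoxy with an amino group at this place does not set the direction on its own. The two amino groups themselves lie far apart, with an at least 39-fold lower number from compound 2 to compound 3 (1.59 log units; beyond the scatter), and since a lower number stands for higher toxicity in this test, compound 3 is the most toxic of the three here. Compound 2 stands at a limit of the assay and not at a number, so the full size of both steps that involve it remains unknown: the limit of > 200000 nM in this assay, at which 1 of the 3 values shown sits.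

The compounds shown leave open whether the higher number of compound 2 goes with its hydroxyl or with the hydrogen kept on its amide nitrogen, a question that a plain ethylamino or a 2-methoxyethylamino group on the same carbonyl carbon would address. They also leave open whether a carboxylic acid at this place, or a cyclic amine such as morpholine on the carbonyl carbon, would fall nearer to compound 2 or to compound 3.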